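Swapping a chlorinated styryl arm for a methoxyphenyl

The compounds below may be only part of what the source reports. "The series", "measured", "known", "first", "only" and "open" are said of these compounds alone.

Measured compounds:
compound 1 `COC(=O)/C=C/c1cccc(N(Cc2ccc(/C=C/c3c(Cl)cccc3Cl)cc2)C(=O)C(C)C)c1` — 195 nM
compound 2 `COC(=O)/C=C/c1cccc(N(Cc2ccc(/C=C/c3c(Cl)cccc3Cl)cc2)C(=O)C2CCCCC2)c1` — 150 nM
compound 3 `COC(=O)/C=C/c1cccc(N(Cc2ccc(/C=C/c3cccc(Cl)c3)cc2)C(=O)C2CCCCC2)c1` — 165 nM

Three compounds built on one shared core were tested in an assay on isolated protein with Bile acid receptor (Homo sapiens) as the target; on this read-out higher numbers stand for an effect only at larger amounts of compound and lower numbers for an effect already at smaller amounts. The three numbers sit very close together: compound 1 has the numerically largest, yet its gaps to compound 2 and compound 3 are both within the scatter, so nothing separates them. The two single-point steps confirm this: a 1.3-fold lower number from compound 1 to compound 2 (0.11 log units; within the scatter) and a 1.1-fold higher number from compound 2 to compound 3 (0.04 log units; within the scatter) are each flat.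

Compound 4 `COC(=O)/C=C/c1cccc(N(Cc2ccc(-c3cccc(OC)c3)cc2)C(=O)C(C)C)c1` differs from compound 1 by 3-methoxyphenyl in place of 2-(2,6-dichlorophenyl)ethenyl on an aromatic carbon. The step from compound 2 to compound 3 is the only one touching this region; there the aromatic ring on the ethenyl chain changed and the number barely moved. Going by the values given here, in compound 4, however, the ethenyl chain is gone altogether and a methoxy group enters, a change no measured step covers. The flat result in that region is weak encouragement, but the shorter arm adds real uncertainty, so a somewhat higher number is expected, a 3.1-fold higher number from compound 1 to compound 4 (0.49 log units; beyond the scatter). Compound 4 is estimated at 600 nM, within 150 nM to 3000 nM.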

Compound 4, half-maximal effective concentration: 72 nM
The estimate for compound 4 lay 8.3-fold (0.92 log units) above the measured number, and the stated range ends above it.
By their numbers in this assay, from the lowest: compound 4; then compounds 2, 3 and 1 (each within the scatter of the next).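

Going by these compounds alone, at this position, on the aromatic ring and para to a large group, the earlier compounds only varied the chlorines on the aromatic ring of the ethenyl arm, and the numbers stayed flat. Compound 4 shows that the whole arm can go: in this assay, 3-methoxyphenyl in place of 2-(2,6-dichlorophenyl)ethenyl gives a 2.7-fold lower number from compound 1 to compound 4 (0.43 log units; beyond the scatter), a modest gain despite the loss of the double bond and both chlorines. Nothing available accounts for this result.

This one change removes the double bond and the chlorines and adds the methoxy group, so the compounds shown cannot separate the part each plays. As far as these compounds go, it also remains open whether a plain phenyl, or a phenyl carrying an amine or a carboxylic acid in place of the methoxy group, would give a similar number.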